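Fluoro for hydrogen on the benzoyl ring of compound 3

The source may report more compounds than this note shows. Statements on the series, on what has been measured and on what is new or still open speak of the compounds shown alone.

Among the measured compounds shown here, compound 3 `COc1cc(-c2nnc3n2NC(c2cccs2)C(C(=O)c2ccccc2)S3)cc(OC)c1OC` gives 69400 nM in a functional assay on A549 cells (Homo sapiens) for cytotoxicity, read by MTT assay, with a stated time of 48 h (a higher number here means a weaker inhibitor, a lower number a stronger inhibitor), the highest of the three numbers so far: compound 1 `COc1cc(-c2nnc3n2NC(c2ccco2)C(C(=O)c2ccc(F)cc2)S3)cc(OC)c1OC` gives 53700 nM, within the scatter of compound 3, while compound 2 `COc1cc(-c2nnc3n2NC(c2cccs2)C(C(=O)c2ccc(C)cc2)S3)cc(OC)c1OC` gives 12700 nM. For the measured compounds named here, the one measured step on the benzoyl ring, a 5.5-fold higher number from compound 2 to compound 3 (0.74 log units; beyond the scatter), is modest. Compound 4 `COc1cc(-c2nnc3n2NC(c2cccs2)C(C(=O)c2ccc(F)cc2)S3)cc(OC)c1OC` differs from compound 3 by fluoro in place of hydrogen on an aromatic carbon. Going by the values given here, no measured step covers this exact change; compound 1 carries the same fluoro with a different five-membered ring and sits within the scatter of compound 3. A small step is therefore expected, a 1.7-fold lower number from compound 3 to compound 4 (0.24 log units; within the scatter), toward a lower number at most. Compound 4 is estimated at 40000 nM, range 12000 nM to 120000 nM.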

Compound 4, half-maximal inhibitory concentration: 45000 nM
For compound 4 the middle estimate is 1.1-fold (0.05 log units) below the measured one, and the stated range covers the measured number.
By their numbers in this assay, from the lowest: compound 2; then compounds 4, 1 and 3 (each within the scatter of the next).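

In this assay, fluoro on the benzoyl ring does not separate from hydrogen (a 1.5-fold lower number from compound 3 to compound 4 (0.19 log units; within the scatter)). Methyl does separate from fluoro (a 3.5-fold higher number from compound 2 to compound 4 (0.55 log units; beyond the scatter)), so among the three groups seen at this position, only the methyl of compound 2 stands apart. With fluoro held fixed, the exchange of the five-membered ring also shows no separation (a 1.2-fold lower number from compound 1 to compound 4 (0.08 log units; within the scatter)).

No measured evidence bears on why methyl stands apart from hydrogen and fluoro. As far as these compounds go, whether an ethyl group or an amine at this position would follow methyl remains open.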